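The compounds below may be only part of what the source reports. "The series", "measured", "known", "first", "only" and "open" are said of these compounds alone.

Measured so far:
compound 1 `Nc1scc(CN2CCN(c3ccc(Cl)cc3Cl)CC2)c1C(=O)c1ccc(Cl)cc1`: -11%
compound 2 `Nc1scc(CN2CCN(c3cc(Cl)cc(Cl)c3)CC2)c1C(=O)c1ccc(Cl)cc1`: -22%

In a functional assay on CHO cells with adenosine receptor A1 (Homo sapiens) as the target, read by cAMP accumulation and immunoassay, with a stated time of 6 min, tested at 0.1 uM (a lower number here means a stronger effect, a higher number a weaker effect of the compound at the concentration tested), compound 1 gives -11% and compound 2 gives -22%. On these two numbers compound 2 stands lowest, with compound 1 the nearer and only neighbour. Going by the values given here, the single step known, a number 11 percentage points lower from compound 1 to compound 2 (beyond the scatter), shows that exchanging the aryl group on the ring nitrogen shifts the read-out modestly.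

Compound 3 `Nc1scc(CN2CCN(c3ccc(Cl)cc3F)CC2)c1C(=O)c1ccc(Cl)cc1` is not yet measured. Its change from compound 2 is 4-chloro-2-fluorophenyl in place of 3,5-dichlorophenyl on an amine nitrogen in a ring. Among the compounds with values here, the only measured step that bears on this is a number 11 percentage points lower from compound 1 to compound 2 (beyond the scatter), where 3,5-dichlorophenyl gave the lower number; 4-chloro-2-fluorophenyl, like 2,4-dichlorophenyl, carries a chlorine at the 4-position, so a modest return upward toward compound 1 is expected rather than a further fall. Compound 3 is therefore estimated at -12%, within -26% to 2%, an expected step of a number 10 percentage points higher from compound 2 to compound 3 (within the scatter).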

Compound 3, a percentage reported as activity, at one concentration (the size of the read-out at that concentration, not a potency): -9.4%
For compound 3 the middle estimate is 2.6 percentage points below the measured one, and the stated range covers the measured number.
By their numbers in this assay, from the lowest: compound 2; then compounds 1 and 3 (each within the scatter of the next).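

In this assay, fluoro in place of chloro on the aromatic ring gives a number 1.6 percentage points higher from compound 1 to compound 3 (within the scatter), so on this evidence the two halogens cannot be told apart in this one place. The exchange of 3,5-dichlorophenyl for 4-chloro-2-fluorophenyl gives a number 12.6 percentage points higher from compound 2 to compound 3 (beyond the scatter), which leaves compound 2 apart from the two compounds whose aryl groups both carry a chlorine at the 4-position, although three compounds are too few to call this a pattern. Nothing measured here explains these differences.

From the compounds shown here alone, it remains open how a phenyl group with no halogen at all, or one bearing a methoxy group, would read in this assay. The compounds shown also cannot tell whether a pyridine ring in place of the phenyl ring would be tolerated on the ring nitrogen.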